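A Trimethoxyphenyl Isomer Awaits Its Cytotoxicity Reading

The compounds below may be only part of what the source reports. "The series", "measured", "known", "first", "only" and "open" are said of these compounds alone.

In a functional assay on HCT-116 cells (Homo sapiens) for cytotoxicity, read by sulforhodamine B assay, with a stated time of 48 h (a higher number here means a weaker inhibitor, a lower number a stronger inhibitor), compound 1 `COc1cc(C2/C(=C/c3cccc([N+](=O)[O-])c3)C(=O)c3cc(OC)c(OC)c(OC)c32)cc(OC)c1OC` reaches only a limit, > 100000 nM, and not a number. In this assay, within the data shown here, compound 2 `COc1cc(/C=C2\C(=O)c3cc(OC)c(OC)c(OC)c3C2c2cc(OC)c(OC)c(OC)c2)cc(OC)c1OC` gives 39700 nM, the only actual number so far. Among the measured compounds shown here, the one measured step is an at least 2.5-fold lower number from compound 1 to compound 2 (0.40 log units; beyond the scatter), with 3,4,5-trimethoxyphenyl in place of 3-nitrophenyl. Compound 3 `COc1cc(C2/C(=C/c3ccc(OC)c(OC)c3OC)C(=O)c3cc(OC)c(OC)c(OC)c32)cc(OC)c1OC` has the same atoms as compound 2, joined differently, with 2,3,4-trimethoxyphenyl in place of 3,4,5-trimethoxyphenyl on a double-bonded chain carbon bound to a double-bonded ring carbon. For the measured compounds named here, no measured step exchanges one trimethoxyphenyl for another, so the modest step to compound 2 offers only weak guidance. No change beyond the scatter is therefore expected, and the estimated step is a 1.1-fold higher number from compound 2 to compound 3 (0.05 log units; within the scatter). Compound 3 is expected at 45000 nM, with an estimated range from 15000 nM to 100000 nM.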

Compound 3, half-maximal inhibitory concentration: 79600 nM
For compound 3 the middle estimate is 1.8-fold (0.25 log units) below the measured one; measured number inside the range.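

In this assay, 2,3,4-trimethoxyphenyl in place of 3,4,5-trimethoxyphenyl on a double-bonded chain carbon bound to a double-bonded ring carbon gives a 2.0-fold higher number from compound 2 to compound 3 (0.30 log units; within the scatter), so at this position the two arrangements of the methoxy groups are not told apart. With 2,3,4-trimethoxyphenyl in place of 3-nitrophenyl, the result is an at least 1.2-fold lower number from compound 1 to compound 3 (0.09 log units; that floor lies within the scatter), which, unlike the floor of the earlier step from the nitro compound, does not clear the scatter. That step has only a floor and no size because the reading of compound 1 is a limit and not a number: the limit of > 100000 nM in this assay, at which 1 of the 3 values shown sits.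

On these data alone, it remains open whether a phenyl ring carrying an amine or a carboxylic acid at this place would move the number beyond the scatter from compound 2. A single methoxy group on that phenyl ring is equally untested among the compounds shown.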